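Triazole-aryl swaps on a diaryl urea series

The source may hold more compounds than are shown below. What is called first, only, known or untested is meant among the compounds shown, and "the series" means these compounds.

Measured so far:
compound 1 `CCc1ccccc1-n1cc(COc2cccc(NC(=O)Nc3ccc(Cl)c(C(F)(F)F)c3)c2)nn1` — 3530 nM
compound 2 `CC(C)c1ccccc1-n1cc(COc2cccc(NC(=O)Nc3ccc(Cl)c(C(F)(F)F)c3)c2)nn1` — 1900 nM
compound 3 `O=C(Nc1cccc(OCc2cn(-c3ccc(Br)cc3)nn2)c1)Nc1ccc(Cl)c(C(F)(F)F)c1` — 2730 nM

All three share the urea core and the triazole linker; they differ only in the aryl group on the triazole nitrogen. In a functional assay on HepG2 cells (Homo sapiens) for inhibition, read by MTT assay, with a stated time of 72 h (on this read-out higher numbers stand for weaker inhibition and lower numbers for stronger inhibition), compound 1 gives 3530 nM, the highest of the three numbers, but the steps of a 1.9-fold lower number from compound 1 to compound 2 (0.27 log units; within the scatter) and a 1.3-fold lower number from compound 1 to compound 3 (0.11 log units; within the scatter) are both within the scatter, so nothing separates the three.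

Compound 4 `O=C(Nc1cccc(OCc2cn(-c3cccc(C(F)(F)F)c3)nn2)c1)Nc1ccc(Cl)c(C(F)(F)F)c1` is not yet measured. It differs from compound 1 by 3-(trifluoromethyl)phenyl in place of 2-ethylphenyl on an aromatic nitrogen. The nearest precedents are a 1.3-fold lower number from compound 1 to compound 3 (0.11 log units; within the scatter) and a 1.4-fold higher number from compound 2 to compound 3 (0.16 log units; within the scatter), both aryl swaps at the same nitrogen and both within the scatter. Nothing in the measured set indicates that the substituent on this aryl ring moves the number beyond the scatter. For compound 4 the expectation is therefore a step of a 1.2-fold lower number from compound 1 to compound 4 (0.07 log units; within the scatter), that is essentially none beyond the scatter, with an estimated value of 3000 nM and a range of 1200 nM to 7500 nM.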

Compound 4, half-maximal inhibitory concentration: 1270 nM
For compound 4 the middle estimate is 2.4-fold (0.37 log units) above the measured one; the range from low to high includes it.
By their numbers in this assay, from the lowest: compounds 4, 2, 3 and 1 (each within the scatter of the next, the first and the last beyond it).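

The aryl group on this aromatic nitrogen can move the number beyond the scatter in this assay: 3-(trifluoromethyl)phenyl gives a 2.8-fold lower number from compound 1 to compound 4 (0.44 log units; beyond the scatter) and a 2.1-fold lower number from compound 3 to compound 4 (0.33 log units; beyond the scatter), whereas the earlier swaps at this position all stayed within it. The separation is not complete, since a 1.5-fold lower number from compound 2 to compound 4 (0.17 log units; within the scatter) leaves compound 4 unresolved from the 2-isopropylphenyl compound, so only compound 1 and compound 3 are distinguished from compound 4. Nothing measured here accounts for the difference between these aryl groups.

The compounds shown do not separate the effect of the trifluoromethyl group itself from that of its place on the ring. From the compounds shown here alone, how an aryl ring bearing an amine or a carboxylic acid would read at this nitrogen remains open.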